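Pyridin-2-yl for 1,3-thiazol-2-yl: expected clearance of compound 4

The source may hold more compounds than are shown below. What is called first, only, known or untested is meant among the compounds shown, and "the series" means these compounds.

Of the compounds shown here, three have been measured in an ADME assay on microsomes from liver (Mus musculus) for metabolic stability; a higher number here means faster removal of the compound, a lower number slower removal. Compound 1 `CN1C(=O)C2=C(C1=O)N(CC(=O)Nc1ccc(-c3cccnc3)nc1)CCC2` gives 17 mL.min-1.g-1, and compound 2 `CN1C(=O)C2=C(C1=O)N(CC(=O)Nc1ccc(-c3ccccc3)nc1)CCC2` gives 13 mL.min-1.g-1. Compound 3 `CN1C(=O)C2=C(C1=O)N(CC(=O)Nc1ccc(-c3nccs3)cc1)CCC2` gives 65 mL.min-1.g-1, the highest of the three and beyond the scatter from both others. It differs from each of them in more than one place, so neither gap can be assigned to a single group.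

Compound 4 `CN1C(=O)C2=C(C1=O)N(CC(=O)Nc1ccc(-c3ccccn3)cc1)CCC2` differs from compound 3 in one group only: pyridin-2-yl in place of 1,3-thiazol-2-yl on an aromatic carbon, para to a large group (pyridin-2-yl in place of 1,3-thiazol-2-yl on an aromatic carbon).

Among the measured compounds shown here, no measured step covers this exchange. The nearest is a 1.3-fold lower number from compound 1 to compound 2 (0.12 log units; within the scatter), with phenyl in place of pyridin-3-yl on an aromatic carbon, and it exchanges one six-membered aromatic ring for another. A small move to lower numbers is still expected, resting on compound 1 at 17 mL.min-1.g-1 and compound 2 at 13 mL.min-1.g-1, which both carry a six-membered aromatic ring in the matching place. Both also differ from compound 3 elsewhere, so this support is weak.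

In this assay the expected step is a 1.4-fold lower number from compound 3 to compound 4 (0.16 log units; within the scatter), not beyond the scatter. For compound 4 the estimate is 45 mL.min-1.g-1, with an expected range of 20 mL.min-1.g-1 to 95 mL.min-1.g-1.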

Compound 4, intrinsic clearance in microsomes: 38 mL.min-1.g-1
The estimate for compound 4 lay 1.2-fold (0.07 log units) above the measured number; the range from low to high includes it.
By their numbers in this assay, from the lowest: compounds 2 and 1 (each within the scatter of the next); then compounds 4 and 3 (each within the scatter of the next).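

In this assay, among the compounds shown here, pyridin-2-yl in place of 1,3-thiazol-2-yl on an aromatic carbon, para to a large group, gives a 1.7-fold lower number from compound 3 to compound 4 (0.23 log units; within the scatter), the first reading of a single exchange on this six-membered aromatic ring of carbon only. A five-membered aromatic ring with 2 hetero atoms and a six-membered aromatic ring with 1 hetero atom are therefore not separated at this position in this read-out, although compound 4 differs from compound 1 and compound 2 in more than one place, so the step cannot be carried over to them. Nothing at hand bears on what lies behind this result.

Open, going by these compounds, is how the read-out responds at this position to a group other than an aromatic ring, such as a morpholine or a primary amine, or to a fluorine or methoxy group added to the pyridin-2-yl ring. Also open, on these data alone, is whether the same exchange gives a similar step on the nitrogen-containing ring that carries this group in compound 1 and compound 2.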